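The source may report more compounds than this note shows. Statements on the series, on what has been measured and on what is new or still open speak of the compounds shown alone.

Compound 1 `CCOC(=O)C1=Cc2ccccc2OC1(OCc1cc(-c2ccc(F)cc2F)no1)C(F)(F)F`: > 150000 nM. Compound 2 `CCOC(=O)C1=Cc2ccccc2OC1(OCc1cn(-c2cccc(OC)c2)nn1)C(F)(F)F`: > 150000 nM.

In a functional assay on MCF7 cells (Homo sapiens) for inhibition, read by MTT assay, with a stated time of 24 h (a higher number here means a weaker inhibitor, a lower number a stronger inhibitor), compound 1 gives > 150000 nM, which is a limit of the assay and not a number. In this assay compound 2 gives > 150000 nM, again a limit. Within the data shown here, compound 2 thus stands at the limit of > 150000 nM in this assay, at which 2 of the 2 values shown sit, and no measured step exists to compare. Compound 3 `CCOC(=O)C1=Cc2ccccc2OC1(OCc1cn(-c2ccc(F)c([N+](=O)[O-])c2)nn1)C(F)(F)F` differs from compound 2 by 4-fluoro-3-nitrophenyl in place of 3-methoxyphenyl on an aromatic nitrogen. Among the measured compounds shown here, with no measured step to guide the change, compound 3 is expected to stay near the limit, and the step from compound 2 to compound 3 of a step that the limit leaves unreadable from compound 2 to compound 3 is expected to be none beyond the scatter. For compound 3 the value is estimated at 200000 nM, between 50000 nM and 1000000 nM.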

Compound 3, half-maximal inhibitory concentration: 16200 nM
Beside the measured number, compound 3's estimate is 12-fold (1.09 log units) above it; measured number below the stated range.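

In this assay the change to 4-fluoro-3-nitrophenyl in place of 3-methoxyphenyl on an aromatic nitrogen gives an at least 9.2-fold lower number from compound 2 to compound 3 (0.96 log units; beyond the scatter) and yields a readable number. So the group on this nitrogen can move the read-out off the limit, which the earlier compounds could not show: the limit of > 150000 nM in this assay, at which 2 of the 3 values shown sit.

The compounds shown do not tell whether the fluorine or the nitro group carries this step. They also leave open what an amine or a carboxylic acid on this phenyl ring would do to the number.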